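The compounds below may be only part of what the source reports. "The series", "measured", "known", "first", "only" and "open" are said of these compounds alone.

Measured so far:
- compound 1, `CC(=O)N(C)c1ccc2[nH]c(-c3n[nH]c4ccccc34)cc2n1`, with 14800 nM in a functional assay on HCT-116 cells (Homo sapiens) for antiproliferative activity, read by MTT assay, with a stated time of 72 h; a lower number here means a stronger inhibitor, a higher number a weaker inhibitor
- compound 2, `Cc1ccc(S(=O)(=O)N(C)c2ccc3[nH]c(-c4n[nH]c5ccccc45)cc3n2)cc1`, with 13300 nM in this assay

Compound 2 stands at the lower of the two numbers, but only by a 1.1-fold lower number from compound 1 to compound 2 (0.05 log units; within the scatter), a step described as within the scatter, so the two compounds cannot be separated on these numbers. Among the measured compounds shown here, that one step, the replacement of acetyl by (4-methylphenyl)sulfonyl on the ring nitrogen, is the only measured comparison in this set.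

Compound 3, `CN(c1ccc2[nH]c(-c3n[nH]c4ccccc34)cc2n1)S(=O)(=O)c1ccc(Cl)cc1`, keeps the sulfonyl attachment of compound 2 and differs from it in one place: chloro in place of methyl on an aromatic carbon. For the measured compounds named here, no measured step touches this position, so the change itself is uninformed by the data. Going by the values given here, the one step that is known, from compound 1 to compound 2, concerns a far larger exchange and still stayed within the scatter, which gives no reason to expect the smaller exchange here to move the number beyond the scatter either. Compound 3 is therefore estimated at 12000 nM, with a range of 5000 nM to 30000 nM, meaning an expected step of a 1.1-fold lower number from compound 2 to compound 3 (0.04 log units; within the scatter).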

Compound 3, half-maximal inhibitory concentration: 5980 nM
Compound 3: middle estimate off by 2.0-fold (0.30 log units), on the high side; measured number inside the range.
By their numbers in this assay, from the lowest: compound 3; then compounds 2 and 1 (each within the scatter of the next).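

In this assay, this position on the six-membered aromatic ring, para to a large group, proves able to move the number: chloro in place of methyl gives a 2.2-fold lower number from compound 2 to compound 3 (0.35 log units; beyond the scatter), a modest step and the first in this set beyond the scatter, although the counts of heavy atoms, donors and acceptors are the same for the two groups. The comparison with the acetyl compound changes as well, since (4-chlorophenyl)sulfonyl in place of acetyl gives a 2.5-fold lower number from compound 1 to compound 3 (0.39 log units; beyond the scatter), also modest and beyond the scatter, while (4-methylphenyl)sulfonyl in place of acetyl gave only a 1.1-fold lower number from compound 1 to compound 2 (0.05 log units; within the scatter). Nothing available explains why this single exchange separates compound 3 from compound 2.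

The compounds shown leave open whether the number would fall further, stay level or rise with another group at this same position, such as fluoro, methoxy, trifluoromethyl or an amine. With only methyl and chloro compared here, they also leave open whether the step reflects something particular to chloro or a wider trend among groups at this position.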